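This account rests on a few compounds, and the source may have more. Where it says the series, first, only, none or still open, it means among the compounds named here.

Compound 1 `CC(=O)NCC#CCn1ccnc1` and compound 2 `CC(=O)NCC#CCn1cncc1C` share one core, and compound 3 `Cn1ccn(CC#CCn2ccnc2)c1=O` carries a different core; the difference between the two cores is not broken down here. In a functional assay on the whole organism for agonist activity, with Mus musculus as the target (on this read-out higher numbers stand for an effect only at larger amounts of compound and lower numbers for an effect already at smaller amounts), compound 1 gives > 100 mg/kg, which is a limit of the assay and not a number, as shown by the limit of > 100 mg/kg in this assay, at which 1 of the 3 values shown sits. In this assay compound 2 gives 66 mg/kg and compound 3 gives 4.4 mg/kg. The change methyl in place of hydrogen on an aromatic carbon made a step of an at least 1.5-fold lower number from compound 1 to compound 2 (0.18 log units; that floor lies within the scatter).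

Compound 4 `Cc1cncn1CC#CCn1ccn(C)c1=O` is not yet measured. It differs from compound 3 by methyl in place of hydrogen on an aromatic carbon, the same kind of change as before, the only difference in the surroundings being that the neighbouring ring atom bears a large group rather than a group of 8 heavy atoms. A step of about a 1.5-fold lower number from compound 3 to compound 4 (0.17 log units; within the scatter) is expected from this assay, resting on compound 1 and compound 2 having shown the step of an at least 1.5-fold lower number from compound 1 to compound 2 (0.18 log units; that floor lies within the scatter), which is small and starts from a limit. For compound 4 the estimate in this assay is therefore 3 mg/kg, expected to lie between 1 mg/kg and 10 mg/kg.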

Compound 4, dose for half-maximal effect: > 100 mg/kg
Compound 4: a limit, no number; the forecaster's own chance of this, stated with the estimate: 5%; at least 33-fold (1.52 log units) between middle value and limit.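

Carried to the core of compound 3, methyl in place of hydrogen on an aromatic carbon gives an at least 22-fold higher number from compound 3 to compound 4 (1.35 log units; beyond the scatter), so on this core a single added carbon goes with a large loss of effect in this assay. Going by these compounds, compound 4 gives > 100 mg/kg, which is a limit of the assay and not a number, so the full size of this step stays unknown. The result of this change on one core therefore cannot be carried over to the other in this series, although a single pair on each core does not show why the two results part: the same change on two cores in this assay, an at least 1.5-fold lower number (0.18 log units; that floor lies within the scatter) from compound 1 to compound 2 and an at least 22-fold higher number (1.35 log units; beyond the scatter) from compound 3 to compound 4, at least 34-fold (1.53 log units) apart, beyond the scatter of two such steps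

The compounds shown leave open whether another group at the same place, such as ethyl, chlorine or an amine, would be tolerated on the core of compound 3. They also leave open whether a longer chain joining the two ring parts would alter the outcome of adding the methyl.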